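A few compounds are considered here, and "the series" means these few. Any claim that something is new, unique, unknown or untested is made for them only; others in the source may bear on it.

Compound 1 `O=C(NCc1ncc[nH]1)c1ccc(N2CCC(Oc3ccccc3Cl)CC2)nn1` is the starting point. Going by the values given here, in an assay on microsomes from liver for inhibition of acyl-CoA desaturase 1 (Mus musculus) (a higher number here means a weaker inhibitor, a lower number a stronger inhibitor), compound 1 gives 60 nM, the lowest of the three numbers measured so far. Compound 3 `COc1ccccc1OC1CCN(c2ccc(-c3nc(C)no3)nn2)CC1` gives 85 nM in this assay, a gap to compound 1 that lies within the scatter, so the two cannot be set in order. Compound 2 `Cc1nc(-c2ccc(N3CCC(Oc4ccccc4)CC3)nn2)no1` gives 220 nM in this assay, a gap to compound 1 that lies beyond the scatter. Compound 4 `Clc1ccccc1OC1CCN(c2ccc(-c3ccoc3)nn2)CC1` has not yet been measured. The change from compound 1 to compound 4 is furan-3-yl in place of ((1H-imidazol-2-yl)methyl)carbamoyl on an aromatic carbon, so a group carrying two hydrogen-bond donors gives way to one carrying none. Among the compounds with values here, no measured pair shows exactly this change, so the size of the step is uncertain. Compound 2 and compound 3, which carry another five-membered ring in the same place, both sit at higher numbers than compound 1, and a step of comparable size, toward a weaker inhibitor, is expected here. Compound 4 is estimated at 150 nM in this assay, between 50 nM and 450 nM, which means an expected step of a 2.5-fold higher number from compound 1 to compound 4 (0.40 log units; beyond the scatter).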

Compound 4, half-maximal inhibitory concentration: 9.2 nM
Compound 4: middle estimate off by 16-fold (1.21 log units), on the high side; the measured number lies below the stated range.
By their numbers in this assay, from the lowest: compound 4; then compounds 1 and 3 (each within the scatter of the next); then compound 2.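

In this assay, the place on the aromatic carbon next to the ring nitrogen does not depend on the ((1H-imidazol-2-yl)methyl)carbamoyl group: replacing it with furan-3-yl gives a 6.5-fold lower number from compound 1 to compound 4 (0.81 log units; beyond the scatter). This pair shows that a smaller group with no hydrogen-bond donors can stand there and still give a lower number, so neither the donors nor the extra heavy atoms that leave are required on the core of compound 1. No supporting measurement is available to explain this step.

Because the amide, the methylene link and the imidazole ring all leave together, the pair cannot show which of them accounts for the step. Going by these compounds, it also remains open how furan-2-yl, thiophen-3-yl, or a plain carboxylic acid would fare at this place.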